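Changing the aryl group on a ring amine nitrogen

The source may hold more compounds than are shown below. What is called first, only, known or untested is meant among the compounds shown, and "the series" means these compounds.

Measured compounds:
compound 1, `CCCc1nc(-c2ccccc2)c(CNCCN2CCN(c3ccc(Cl)cc3)CC2)o1`: 2820 nM
compound 2, `CCCc1nc(-c2ccccc2)c(CNCCCN2CCN(c3cccc(F)c3)CC2)o1`: 3030 nM

Of the compounds shown here, two sharing the same core have been measured in an assay on HEK293 cells for inhibition of Voltage-dependent T-type calcium channel subunit alpha-1G (Homo sapiens), read by patch clamp; a lower number here means a stronger inhibitor, a higher number a weaker inhibitor. Compound 1 gives 2820 nM in this assay. Compound 2 gives 3030 nM in this assay, the higher of the two numbers, but its gap to compound 1 lies within the scatter of repeated measurements, so the two cannot be ordered.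

Compound 3, `CCCc1nc(-c2ccccc2)c(CNCCCN2CCN(c3ccccc3C)CC2)o1`, has not yet been measured. It differs from compound 2 in one place: 2-methylphenyl in place of 3-fluorophenyl on an amine nitrogen in a ring. Within the data shown here, the two measured compounds differ from each other in more than one place, so no single step has been isolated and no size of change for an aryl swap of this kind can be read from them. Both measured numbers sit close together in this assay, and nothing points to a large shift in either direction.

Compound 3 is therefore expected to land near compound 2, with a 1.1-fold higher number from compound 2 to compound 3 (0.02 log units; within the scatter) estimated to fall within the scatter. The estimate for compound 3 in this assay is 3200 nM, with a range from 1200 nM to 8500 nM.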

Compound 3, half-maximal inhibitory concentration: 8750 nM
The estimate for compound 3 lay 2.7-fold (0.44 log units) below the measured number; the whole stated range lies below it.
By their numbers in this assay, from the lowest: compounds 1 and 2 (each within the scatter of the next); then compound 3.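

In this assay, putting 2-methylphenyl in place of 3-fluorophenyl on an amine nitrogen in a ring gives a 2.9-fold higher number from compound 2 to compound 3 (0.46 log units; beyond the scatter) and is a modest step, the only one here that isolates a single change. It shows that the number responds to the aryl group at this position: the two groups have the same count of heavy atoms, each holds one six-membered aromatic ring of carbon only, and neither has a hydrogen-bond donor or acceptor, so these shared counts do not fix the value. No measurement at hand gives a reason for this step.

From the compounds shown here alone, this single swap alters both the substituent and where it sits on the phenyl ring, so it remains open which of the two carries the step, a question that 3-methylphenyl or 2-fluorophenyl on the same nitrogen would address. Also open, going by these compounds, are how an unsubstituted phenyl would stand here and whether 2-methylphenyl would give a similar step on the chain of compound 1.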